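The source may report more compounds than this note shows. Statements on the series, on what has been measured and on what is new or still open speak of the compounds shown alone.

Within the data shown here, compound 2, with the structure `CC[C@@](C)(O)CC(=O)O[C@H](CC=C(C)C)C1=CC(=O)c2c(O)ccc(O)c2C1=O`, is the only member of this set that gives a number in a functional assay on DU-145 cells (Homo sapiens) for cytotoxicity, read by MTT assay; on this read-out lower numbers stand for stronger inhibition and higher numbers for weaker inhibition: there compound 2 gives 12700 nM. Compound 1, `CC(C)=CC[C@@H](OC(=O)c1ccoc1)C1=CC(=O)c2c(O)ccc(O)c2C1=O`, gives only a limit in this assay, namely > 100000 nM. Compound 3, `CC(C)=CC[C@@H](OC(=O)c1ccco1)C1=CC(=O)c2c(O)ccc(O)c2C1=O`, likewise gives a limit, > 100000 nM. The two measured steps that can be read are an at least 7.8-fold lower number from compound 1 to compound 2 (0.89 log units; beyond the scatter) and an at least 7.8-fold higher number from compound 2 to compound 3 (0.89 log units; beyond the scatter), both resting on (the limit of > 100000 nM in this assay, at which 2 of the 3 values shown sit); the pair of compound 1 and compound 3 shows a step that the two limits leave unreadable from compound 1 to compound 3.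

Compound 4, `CCCCC(CC(=O)O[C@H](CC=C(C)C)C1=CC(=O)c2c(O)ccc(O)c2C1=O)OC(C)=O`, differs from compound 2 by 1-acetoxypentyl in place of 1-hydroxy-1-methylpropyl on a saturated chain carbon bound to a carbonyl carbon. Both readable steps concern an exchange of a saturated chain for a furan ring, so neither covers the present change, which keeps a chain on the carbonyl carbon. The expectation is therefore a step of modest size at most, probably toward a higher number, as a 1.7-fold higher number from compound 2 to compound 4 (0.24 log units; within the scatter). Compound 4 is estimated at 22000 nM, expected to lie between 6000 nM and 80000 nM.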

Compound 4, half-maximal inhibitory concentration: 67700 nM
Estimate against measurement, compound 4: 3.1-fold (0.49 log units) below; low and high end bracket the measured number.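

Among these compounds, the position also responds to a change that keeps a chain: in this assay, 1-acetoxypentyl in place of 1-hydroxy-1-methylpropyl gives a 5.3-fold higher number from compound 2 to compound 4 (0.73 log units; beyond the scatter), so exchanging a chain for a furan ring is not the only change here that moves the number. The 2-acetoxyhexyl group in place of either furan ring gives an at least 1.4-fold lower number from compound 3 to compound 4 (0.16 log units; that floor lies within the scatter) and an at least 1.4-fold lower number from compound 1 to compound 4 (0.16 log units; that floor lies within the scatter), and these floors leave open how far it truly stands from the furan esters. Both of these steps rest on a limit and not on a number: the limit of > 100000 nM in this assay, at which 2 of the 4 values shown sit.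

The exchange alters the oxygen substituent and the chain together, so the compounds shown do not tell which of the two carries the step. A 2-hydroxyhexyl group on the carbonyl carbon, with a free hydroxyl on the longer chain, would separate them.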